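Dichloro Substitution on the Quinolinyl Ether of Compound 3

A few compounds are considered here, and "the series" means these few. Any claim that something is new, unique, unknown or untested is made for them only; others in the source may bear on it.

Compound 1 `C=C1CC[C@H]2[C@@](C)(CCC(=O)[C@@]2(C)COC(C)=O)[C@@H]1C/C=C1/C(=O)OC[C@H]1Oc1c(Cl)cc(Cl)c2cccnc12`: > 100000 nM
Compound 2 `C=C1CC[C@@H]2[C@](C)(CO)[C@H](O)CC[C@@]2(C)[C@@H]1C/C=C1/C(=O)OC[C@H]1Oc1cccnc1[N+](=O)[O-]`: 67700 nM
Compound 3 `C=C1CC[C@@H]2[C@](C)(COC(C)=O)[C@H](O)CC[C@@]2(C)[C@@H]1C/C=C1/C(=O)OC[C@@H]1Oc1cccc2cccnc12`: 49500 nM

These three compounds were tested in an ADME assay on SNB-19 cells (Homo sapiens) for cytotoxicity, read by MTT assay, with a stated time of 24 h; a lower number here means that less compound is tolerated, a higher number that more compound is tolerated. Compound 1 reached only the limit of the assay, at > 100000 nM, so no number is known for it (the limit of > 100000 nM in this assay, at which 1 of the 3 values shown sits). In this assay compound 2 gives 67700 nM. Compound 3 gives 49500 nM in this assay, which sits within the usual scatter of the value of compound 2, so the two cannot be told apart. Within the data shown here, since one of the three results is a limit, compound 3 stands at one of only two numbers.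

Compound 4 `C=C1CC[C@@H]2[C@](C)(COC(C)=O)[C@H](O)CC[C@@]2(C)[C@@H]1C/C=C1/C(=O)OC[C@@H]1Oc1c(Cl)cc(Cl)c2cccnc12` differs from compound 3 in one place: 5,7-dichloroquinolin-8-yl in place of quinolin-8-yl on an oxygen on a saturated carbon. Among the measured compounds shown here, no pair of measured compounds shows this change directly. Compound 1, which also carries the 5,7-dichloroquinolin-8-yl group on a different core, gave only the limit > 100000 nM. The step from compound 3 to compound 4 is therefore expected to be small, at most modest and towards a higher number, a 1.4-fold higher number from compound 3 to compound 4 (0.15 log units; within the scatter). Compound 4 is estimated at 70000 nM, between 30000 nM and 150000 nM, with a real chance that the assay reports only a limit.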

Compound 4, half-maximal cytotoxic concentration: 39300 nM
Compound 4: middle estimate off by 1.8-fold (0.25 log units), on the high side, within the range that was stated.
By their numbers in this assay, from the lowest: compounds 4, 3 and 2 (each within the scatter of the next). At a limit, above all of these: compound 1.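

Among these compounds, replacing quinolin-8-yl with 5,7-dichloroquinolin-8-yl on the oxygen gives a 1.3-fold lower number from compound 3 to compound 4 (0.10 log units; within the scatter), the first direct reading of this change. At this position on the shared core, then, the two added chlorines leave the number indistinguishable from that of the unsubstituted group, and the 5,7-dichloroquinolin-8-yl group is compatible with a measured value rather than a limit. Compound 1 carries the same group but differs from compound 4 elsewhere as well, so its limit cannot be read as an effect of this change: the limit of > 100000 nM in this assay, at which 1 of the 4 values shown sits.

This single pair cannot show whether a methoxy group or an amine on the quinolin-8-yl group would move the number beyond the scatter. It also leaves open whether the same chlorine exchange would give a similarly small step on another core.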